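A Fluorine Added to the Fused Ring of Compound 2

The compounds below may be only part of what the source reports. "The series", "measured", "known", "first", "only" and "open" are said of these compounds alone.

Three measured compounds share one core and differ only in the aryl group carried on it. Compound 1 `COc1cc2c(Oc3ccc(NC(=O)c4cc(-c5ccccc5)nc5ccccc45)cc3F)ccnc2cc1OCCCN1CCCCC1` gives 110 nM in a functional assay on NCI-H460 cells (Homo sapiens) for cytotoxicity, read by MTT assay, with a stated time of 72 h; a higher number here means a weaker inhibitor, a lower number a stronger inhibitor. Compound 2 `COc1cccc(-c2cc(C(=O)Nc3ccc(Oc4ccnc5cc(OCCCN6CCCCC6)c(OC)cc45)c(F)c3)c3ccccc3n2)c1` gives 210 nM in this assay, and compound 3 `COc1cc2c(Oc3ccc(NC(=O)c4cc(-c5ccc(Cl)c(Cl)c5)nc5ccccc45)cc3F)ccnc2cc1OCCCN1CCCCC1` gives 820 nM. Compound 2 holds the second highest of these three numbers: the step of a 1.9-fold higher number from compound 1 to compound 2 (0.28 log units; within the scatter) leaves it within the scatter of compound 1, while the steps of a 3.9-fold higher number from compound 2 to compound 3 (0.59 log units; beyond the scatter) and a 7.5-fold higher number from compound 1 to compound 3 (0.87 log units; beyond the scatter) set compound 3 apart from both.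

Compound 4 `COc1cccc(-c2cc(C(=O)Nc3ccc(Oc4ccnc5cc(OCCCN6CCCCC6)c(OC)cc45)c(F)c3)c3cc(F)ccc3n2)c1` is not yet measured. It keeps the 3-methoxyphenyl group of compound 2 and alters another place: fluoro in place of hydrogen on an aromatic carbon. Going by the values given here, all three measured steps concern the aryl group attached to the core, and none alters the fused ring itself, so no measured step bears directly on this change. With no guide in the numbers, the change is expected to give no step beyond the scatter. The estimated step is a 1.1-fold higher number from compound 2 to compound 4 (0.04 log units; within the scatter). For compound 4 the estimate in this assay is 230 nM, with a range from 100 nM to 520 nM.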

Compound 4, half-maximal inhibitory concentration: 1000 nM
Beside the measured number, compound 4's estimate is 4.3-fold (0.64 log units) below it; measured number outside the range, above it.
By their numbers in this assay, from the lowest: compounds 1 and 2 (each within the scatter of the next); then compounds 3 and 4 (each within the scatter of the next).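

In this assay the fused ring of the shared core turns out to matter: fluoro in place of hydrogen, an entering group of a single heavy atom with no ring and no net charge, gives a 4.8-fold higher number from compound 2 to compound 4 (0.68 log units; beyond the scatter). Going by these compounds alone, the earlier steps all concerned the aryl group, so this is the first sign that the numbers also respond at this carbon, on the six-membered aromatic ring of carbon only that is part of a fused system of two rings, and that even the smallest of replacements there can produce a step beyond the scatter. The data shown offer no measurement that explains why this replacement moves the number.

Going by these compounds, it remains open whether an amine, a hydroxyl or a nitrile on this same carbon would move the number as fluoro does, and whether fluoro would give a similar step with the phenyl group of compound 1 in place of the 3-methoxyphenyl group of compound 2. Only this one carbon of the ring is represented, so the step cannot be extended to the other carbons of the ring.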